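Taking the methyl group off compound 2

This account rests on a few compounds, and the source may have more. Where it says the series, first, only, none or still open, it means among the compounds named here.

Compound 1 `CCc1ccc(-c2nc3c(c(C)nn3-c3ccccc3)c(-c3ccccc3F)c2C#N)cc1`: 1700 nM
Compound 2 `CCc1ccc(-c2nc3c(c(C)nn3-c3ccccc3)c(-c3ccccc3C)c2C#N)cc1`: 6000 nM

Among the measured compounds shown here, in a physicochemical assay for solubility, read by spectrophotometry, in phosphate buffer, with a stated time of 18 h, at pH 7.4 (a higher number here means a more soluble compound, a lower number a less soluble compound), compound 2 gives 6000 nM, the higher of the two numbers so far, and the gap down to compound 1 lies beyond the scatter. Compound 3 `CCc1ccc(-c2nc3c(c(C)nn3-c3ccccc3)c(-c3ccccc3)c2C#N)cc1` has not been measured yet. Its difference from compound 2 is hydrogen in place of methyl on an aromatic carbon, which turns 2-methylphenyl into phenyl.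

For the measured compounds named here, only one measured step bears on this: a 3.5-fold higher number from compound 1 to compound 2 (0.55 log units; beyond the scatter), with methyl in place of fluoro on an aromatic carbon. That step is modest and does not involve hydrogen, so it is only a loose guide. Since compound 2 is the higher of the two, losing its methyl is expected to bring a modest fall. The estimated step is a 2.4-fold lower number from compound 2 to compound 3 (0.38 log units; beyond the scatter). For compound 3 the expected value is 2500 nM, with an estimated range of 800 nM to 7000 nM.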

Compound 3, solubility: 47000 nM
The estimate for compound 3 lay 19-fold (1.27 log units) below the measured number, and the stated range ends below it.
By their numbers in this assay, from the lowest: compound 1; then compound 2; then compound 3.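

In this assay, hydrogen on this aromatic carbon, ortho to a large group, gives the highest number of the three: replacing methyl with hydrogen gives a 7.8-fold higher number from compound 2 to compound 3 (0.89 log units; beyond the scatter), and replacing fluoro with hydrogen gives a 28-fold higher number from compound 1 to compound 3 (1.44 log units; beyond the scatter). The earlier comparison of fluoro with methyl could not show this: methyl stood above fluoro, yet both substituted compounds stand well below the plain phenyl compound, so methyl is no gain over having no group here. Nothing measured here explains why the numbers move this way.

Still open, on these data alone, is whether any group at this place can match hydrogen, such as a methoxy group, a chlorine or an amine. The compounds shown also leave open whether the same pattern holds elsewhere on this ring.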